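Lengthening the chain of compound 2

The compounds below may be only part of what the source reports. "The series", "measured", "known", "first", "only" and "open" are said of these compounds alone.

Measured in a functional assay on HCT-116 cells (Homo sapiens) for antiproliferative activity, read by MTT assay, with a stated time of 48 h; on this read-out higher numbers stand for weaker inhibition and lower numbers for stronger inhibition:
- Compound 1 `CCCCCC(CCO)n1cnc2c(Cl)ncnc21`: > 50000 nM, a limit of the assay
- Compound 2 `CCCCCC(CCO)n1c(Br)nc2c(Cl)ncnc21`: 18300 nM
- Compound 3 `CCCCCCC(CCO)n1cnc2c(N(C)C)ncnc21`: > 50000 nM, a limit of the assay

Among the compounds with values here, compound 2, at 18300 nM, is the only compound here with an actual number. The other two results are limits. Those two both sit at the limit of > 50000 nM in this assay, at which 2 of the 3 values shown sit.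

Compound 4 `CCCCCCCCC(CCO)n1c(Br)nc2c(Cl)ncnc21` keeps the structure of compound 2 except for one change on the chain: propyl in place of hydrogen on a saturated chain carbon, six bonds along the chain from an aromatic nitrogen.

Within the data shown here, only one measured step connects these compounds. Putting bromo in place of hydrogen on an aromatic carbon gave an at least 2.7-fold lower number from compound 1 to compound 2 (0.43 log units; beyond the scatter). That change lies elsewhere in the molecule, so it offers only a rough sense of size. Among the measured compounds shown here, no measured step isolates a change in the chain, which leaves the direction a tentative call.

A modest move toward a lower number in this assay is expected, and the estimate is a 2.3-fold lower number from compound 2 to compound 4 (0.36 log units; beyond the scatter). For compound 4 the estimated value is 8000 nM, with an expected range of 2500 nM to 25000 nM.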

Compound 4, half-maximal inhibitory concentration: 22400 nM
For compound 4 the middle estimate is 2.8-fold (0.45 log units) below the measured one; the range from low to high includes it.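

The step of a 1.2-fold higher number from compound 2 to compound 4 (0.09 log units; within the scatter) in this assay is the first one shown that isolates a change in the chain. Propyl in place of hydrogen at this place on the saturated chain gives two values that cannot be told apart, so this added length has no readable effect on the number, at least on a core that carries the bromo. The bromo step therefore remains the only change shown with a size beyond the scatter, and few of the results can be read as actual numbers: the limit of > 50000 nM in this assay, at which 2 of the 4 values shown sit.

On these data alone, whether a longer chain still would shift the number remains open. So does whether a carboxylic acid in place of the alcohol would shift it, or whether the propyl change would behave in the same way without the bromo.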